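A few compounds are considered here, and "the series" means these few. Any claim that something is new, unique, unknown or untested is made for them only; others in the source may bear on it.

Three compounds have been measured in a functional assay on VCaP cells (Homo sapiens) for antiproliferative activity, read by propidium iodide staining, with a stated time of 96 h; a higher number here means a weaker inhibitor, a lower number a stronger inhibitor:

Compound 1, `CC(O)(CSc1cccc(S(F)(F)(F)(F)F)c1)C(=O)Nc1cccc(S(F)(F)(F)(F)F)c1`: 29000 nM
Compound 2, `CC(O)(CSc1cccc(C(F)(F)F)c1)C(=O)Nc1cccc(S(F)(F)(F)(F)F)c1`: 20200 nM
Compound 3, `CC(O)(COc1ccc(S(F)(F)(F)(F)F)cc1)C(=O)Nc1cccc(S(F)(F)(F)(F)F)c1`: 8000 nM

Compound 2 differs from compound 1 in one place: a group of 4 heavy atoms (1 carbon, 3 fluorine; no ring) in place of a group of 6 heavy atoms (5 fluorine, 1 sulfur; no ring), on an aromatic carbon. This change gave a 1.4-fold lower number from compound 1 to compound 2 (0.16 log units; within the scatter). Compound 3 rests on a different core; how that core differs from the core of compound 1 is not broken down here. Compound 3 gives the lowest number of the three, and both its gap to compound 2 and its gap to compound 1 lie beyond the scatter.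

Compound 4, `CC(O)(COc1ccc(C(F)(F)F)cc1)C(=O)Nc1cccc(S(F)(F)(F)(F)F)c1`, has not yet been measured. It differs from compound 3 in one place: a group of 4 heavy atoms (1 carbon, 3 fluorine; no ring) in place of a group of 6 heavy atoms (5 fluorine, 1 sulfur; no ring), on an aromatic carbon. This is the same kind of change as from compound 1 to compound 2, but the place differs: there the group sits meta to a large group, here para to a large group.

For the measured compounds named here, the only guide is the step from compound 1 to compound 2, which stayed within the scatter. Compound 4 is therefore expected to stay close to compound 3, with an estimated step of a 1.2-fold lower number from compound 3 to compound 4 (0.09 log units; within the scatter), because a 1.4-fold lower number from compound 1 to compound 2 (0.16 log units; within the scatter). The estimate for compound 4 in this assay is 6500 nM, between 2500 nM and 16000 nM.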

Compound 4, half-maximal inhibitory concentration: 13300 nM
Compound 4: the middle estimate sits 2.0-fold (0.31 log units) below what was measured; the range from low to high includes it.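

In this assay, putting trifluoromethyl in place of the group of five fluorine atoms on sulfur gave a 1.7-fold higher number from compound 3 to compound 4 (0.22 log units; within the scatter). Set beside the same change on the core of compound 1, the two steps do not differ by more than the usual scatter of two such steps: the same change on two cores in this assay, a 1.4-fold lower number (0.16 log units; within the scatter) from compound 1 to compound 2 and a 1.7-fold higher number (0.22 log units; within the scatter) from compound 3 to compound 4, 2.4-fold (0.38 log units) apart, within the scatter of two such steps. On these two cores, then, the change stays within the scatter, and the opposite directions of the two steps cannot be read as a real difference between the cores, but two pairs do not show that the change would behave the same way on any other core.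

The compounds shown leave open whether a different group in this place, such as a chlorine atom, a nitrile or a methyl group, would move the number beyond the scatter. They also leave open what the same change would do on the other aromatic ring, where the group of five fluorine atoms on sulfur stays in all four compounds.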